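The compounds below may be only part of what the source reports. "The series", "measured", "known", "first", "only" and "open" are said of these compounds alone.

Compound 1 `COc1cccc(-n2cc(COc3ccc(/C=C4\C[C@]5(C)[C@@H](CC/C=C(\C)CC/C=C(\C)CCC=C(C)C)[C@](C)(O)CC[C@H]5C(C)(C)C4=O)cc3)nn2)c1` gives 16200 nM in a functional assay on HeLa cells (Homo sapiens) for cytotoxicity, read by MTT assay, with a stated time of 48 h; on this read-out higher numbers stand for weaker inhibition and lower numbers for stronger inhibition.
Compound 2 `CC(C)=CCC/C(C)=C/CC/C(C)=C/CC[C@@H]1[C@@]2(C)C/C(=C\c3ccc(OCc4cn(-c5cccc(O)c5)nn4)cc3)C(=O)C(C)(C)[C@@H]2CC[C@@]1(C)O` gives 158000 nM in this assay.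

Of these two numbers, compound 2 stands highest, with compound 1 the nearest at a lower number. Compound 3 `COc1cc(OC)c(-n2cc(COc3ccc(/C=C4\C[C@]5(C)[C@@H](CC/C=C(\C)CC/C=C(\C)CCC=C(C)C)[C@](C)(O)CC[C@H]5C(C)(C)C4=O)cc3)nn2)c(OC)c1` differs from compound 2 by 2,4,6-trimethoxyphenyl in place of 3-hydroxyphenyl on an aromatic nitrogen. Among the compounds with values here, the only measured step bearing on this change is a 9.8-fold higher number from compound 1 to compound 2 (0.99 log units; beyond the scatter), where hydrogen replaced methyl on an oxygen on an aromatic ring; the step to compound 3 runs the other way, bringing in a 2,4,6-trimethoxyphenyl without a hydroxy group. A lower number is therefore expected in this assay, roughly a 7.9-fold lower number from compound 2 to compound 3 (0.90 log units; beyond the scatter). Compound 3 is estimated at 20000 nM, within 5000 nM to 80000 nM.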

Compound 3, half-maximal inhibitory concentration: 17500 nM
The estimate for compound 3 lay 1.1-fold (0.06 log units) above the measured number; the range from low to high includes it.
By their numbers in this assay, from the lowest: compounds 1 and 3 (each within the scatter of the next); then compound 2.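

In this assay, replacing the 3-hydroxyphenyl on the aromatic nitrogen with 2,4,6-trimethoxyphenyl gives a 9.0-fold lower number from compound 2 to compound 3 (0.96 log units; beyond the scatter). This shows that a second methoxy-bearing ring, not only 3-methoxyphenyl, gives a number far from that of the hydroxy compound. Set against 3-methoxyphenyl, the same group gives a 1.1-fold higher number from compound 1 to compound 3 (0.03 log units; within the scatter), so the two methoxy-bearing rings cannot be told apart here. Nothing measured here explains either step. The compounds shown leave open how an amine or a carboxylic acid on this phenyl ring would read in this assay.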